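The source may hold more compounds than are shown below. What is called first, only, known or untested is meant among the compounds shown, and "the series" means these compounds.

Three close relatives share one core, differing only in the group on one carbon of the three-nitrogen ring. Compound 1 `COc1ncnc(Nc2ccc(Cl)c(OCC=C(C)C)c2)n1` carries hydrogen there and, in an ADME assay on MT2 cells (Homo sapiens) for cytotoxicity (on this read-out higher numbers stand for lower toxicity in this test and lower numbers for higher toxicity in this test), compound 1 gives 18000 nM. Compound 2 `COc1nc(Cl)nc(Nc2ccc(Cl)c(OCC=C(C)C)c2)n1` carries chloro at the same place, and compound 2 gives 26000 nM. Compound 3 `COc1nc(C)nc(Nc2ccc(Cl)c(OCC=C(C)C)c2)n1` carries methyl, and compound 3 gives 12000 nM, the lowest of the three numbers, although the gap to compound 1 is within the scatter, while a 2.2-fold lower number from compound 2 to compound 3 (0.34 log units; beyond the scatter).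

Compound 4 `COc1nc(Nc2ccc(Cl)c(OCC=C(C)C)c2)nc(OC)n1` differs from compound 3 in that a (methoxy in place of methyl on an aromatic carbon). Among the compounds with values here, no measured pair shows methoxy entering at this position, so the nearest guides are the two steps that change this same carbon: a 1.5-fold lower number from compound 1 to compound 3 (0.18 log units; within the scatter), and a 2.2-fold lower number from compound 2 to compound 3 (0.34 log units; beyond the scatter). Both are small, and swapping one small group for another at this carbon has so far moved the number little. Within the data shown here, the methoxy group brings one hydrogen-bond acceptor that methyl lacks, but the data give no step to show what that does here.

Compound 4 is therefore expected to land close to compound 3, with a 1.3-fold higher number from compound 3 to compound 4 (0.10 log units; within the scatter) estimated as no more than a modest shift in either direction. The estimate for compound 4 is 15000 nM, with a likely range from 7000 nM to 32000 nM.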

Compound 4, half-maximal cytotoxic concentration: 20000 nM
Estimate against measurement, compound 4: 1.3-fold (0.12 log units) below, within the range that was stated.
By their numbers in this assay, from the lowest: compounds 3, 1, 4 and 2 (each within the scatter of the next, the first and the last beyond it).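

Methoxy counts one hydrogen-bond acceptor where methyl counts none, yet in this assay this change gives only a 1.7-fold higher number from compound 3 to compound 4 (0.22 log units; within the scatter). The comparisons with the other two groups at this carbon also stay within the scatter: a 1.3-fold lower number from compound 2 to compound 4 (0.11 log units; within the scatter) and a 1.1-fold higher number from compound 1 to compound 4 (0.05 log units; within the scatter). Compound 4 therefore cannot be told apart from any of the three earlier compounds, and a 2.2-fold lower number from compound 2 to compound 3 (0.34 log units; beyond the scatter) remains the only step at this position that lies beyond the scatter, while no measurement shown here explains the pattern.

As far as these compounds go, whether an amine, a carboxylic acid or a longer chain such as butoxy, on this same carbon between two ring nitrogen atoms, would also leave this assay within this narrow band remains open. From the compounds shown here alone, all four compounds also keep the rest of the core unchanged, so it is unknown whether methoxy and methyl would still be indistinguishable here if the other methoxy group were replaced, for example by an ethoxy group.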